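Chloro to Fluoro on the Triazole Aryl Ring

A few compounds are considered here, and "the series" means these few. Any claim that something is new, unique, unknown or untested is made for them only; others in the source may bear on it.

Compound 2 `C=C1C(=O)[C@]23C[C@@]1(O)CC[C@H]2c1ccc(OS(=O)(=O)c2ccc(C)cc2)c(C)c1[C@@H]3Cn1cc(-c2ccc(Cl)cc2)nn1` stands at the highest of three numbers in a functional assay on SW480 cells (Homo sapiens) for cytotoxicity, read by MTT assay, with a stated time of 4 days (on this read-out lower numbers stand for stronger inhibition and higher numbers for weaker inhibition), where compound 2 gives 2390 nM. In this assay compound 1 `C=C1C(=O)[C@]23C[C@@]1(O)CC[C@H]2c1ccc(OS(=O)(=O)c2ccc(C)cc2)c(C)c1[C@@H]3Cn1cc(-c2ccc(Br)cc2)nn1` gives 1590 nM, and compound 3 `C=C1C(=O)[C@]23C[C@@]1(O)CC[C@H]2c1ccc(O)c(C)c1[C@@H]3Cn1cc(-c2ccc(Cl)cc2)nn1` gives 280 nM. The step of a 1.5-fold higher number from compound 1 to compound 2 (0.18 log units; within the scatter) involved chloro in place of bromo, while an 8.5-fold lower number from compound 2 to compound 3 (0.93 log units; beyond the scatter) came from hydrogen in place of (4-methylphenyl)sulfonyl, a part left untouched here. Compound 4 `C=C1C(=O)[C@]23C[C@@]1(O)CC[C@H]2c1ccc(OS(=O)(=O)c2ccc(C)cc2)c(C)c1[C@@H]3Cn1cc(-c2ccc(F)cc2)nn1` differs from compound 2 by fluoro in place of chloro on an aromatic carbon. Going by the values given here, only the step from compound 1 to compound 2 bears on this change, and it stayed within the scatter, so no step beyond the scatter is expected in this assay. Compound 4 is therefore estimated at 2400 nM, with a range from 1100 nM to 5200 nM, an expected step of a 1.0-fold higher number from compound 2 to compound 4 (0.00 log units; within the scatter).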

Compound 4, half-maximal inhibitory concentration: 1630 nM
The estimate for compound 4 lay 1.5-fold (0.17 log units) above the measured number; the range from low to high includes it.
By their numbers in this assay, from the lowest: compound 3; then compounds 1, 4 and 2 (each within the scatter of the next).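

In this assay, fluoro at this position gives a 1.5-fold lower number from compound 2 to compound 4 (0.17 log units; within the scatter), and a 1.0-fold higher number from compound 1 to compound 4 (0.01 log units; within the scatter). Together with the earlier bromo-to-chloro step, this means that bromo, chloro and fluoro on this aromatic carbon cannot be told apart in this read-out. No supporting data bear on this result.

Going by these compounds, what remains open is whether a non-halogen group here, such as an amine or a carboxylic acid, would shift the number beyond the scatter. The compounds shown also leave open whether fluoro would read the same alongside the free hydroxyl of compound 3.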